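This account rests on a few compounds, and the source may have more. Where it says the series, first, only, none or still open, it means among the compounds named here.

Measured compounds:
compound 1 `Cc1ccc2ccc(-c3cccnc3)cc2n1` — 510 nM
compound 2 `COCc1cccc(-c2ccc3ccc(C)nc3c2)c1` — 5800 nM
compound 3 `Cc1ccc2ccc(-c3cccc(Cl)c3)cc2n1` — 14000 nM

Three compounds share one core and differ only in the aryl group attached to it. In a functional assay on CHO cells for inhibition of metabotropic glutamate receptor 5 (Rattus norvegicus), read by FLIPR and calcium flux (on this read-out higher numbers stand for weaker inhibition and lower numbers for stronger inhibition), compound 1 gives 510 nM. Compound 2 stands second highest of the three numbers: its nearest neighbour is compound 3, reached by a 2.4-fold higher number from compound 2 to compound 3 (0.38 log units; beyond the scatter), while compound 1 lies furthest off, with a lower number that is beyond the scatter.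

Compound 4 `Cc1ccc2ccc(-c3cccc(O)c3)cc2n1` has not been measured. It differs from compound 2 in one place: hydroxy in place of methoxymethyl on an aromatic carbon. For the measured compounds named here, no measured step swaps in a hydroxy group, so nothing bears directly on this change. Going by the values given here, the only step at the same position, from compound 2 to compound 3, was modest and went to a higher number. A small step in either direction, or none beyond the scatter, is therefore expected in this assay. Compound 4 is estimated at 4500 nM, with a range of 1200 nM to 16000 nM. That estimate means a step of a 1.3-fold lower number from compound 2 to compound 4 (0.11 log units; within the scatter).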

Compound 4, half-maximal inhibitory concentration: 19000 nM
Compound 4: the middle estimate sits 4.2-fold (0.63 log units) below what was measured; measured number outside the range, above it.
By their numbers in this assay, from the lowest: compound 1; then compound 2; then compounds 3 and 4 (each within the scatter of the next).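

In this assay, the change to hydroxy gives a 3.3-fold higher number from compound 2 to compound 4 (0.52 log units; beyond the scatter), so a second group in place of methoxymethyl on this aromatic carbon also moves to a higher number, as chloro did with a 2.4-fold higher number from compound 2 to compound 3 (0.38 log units; beyond the scatter). The swap between the two replacements gives a 1.4-fold higher number from compound 3 to compound 4 (0.13 log units; within the scatter), which lies within the scatter, so this assay does not separate hydroxy from chloro here, and compound 2 keeps the lowest number of the three compounds that carry these groups. No evidence is available that explains this result.

Going by these compounds, whether the lower number of compound 2 goes with the length of its chain or with the oxygen held within it stays open. A propyl group or a longer ether chain such as methoxyethyl at this place would bear on that, and an amine or a carboxylic acid there remains unexplored in the compounds shown.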